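This account rests on a few compounds, and the source may have more. Where it says the series, first, only, none or still open, it means among the compounds named here.

Measured compounds:
- compound 1 `O=S(=O)(NC1=NCCN1C(=S)SN1CCn2c1nsc2=S)c1ccccc1`; in a functional assay on KYSE-510 cells (Homo sapiens) for antiproliferative activity, read by crystal violet staining, with a stated time of 96 h (a lower number here means a stronger inhibitor of growth, a higher number a weaker inhibitor of growth), compound 1 gives >= 20000 nM, a limit of the assay.
- compound 2 `COc1cc(C)ccc1S(=O)(=O)NC1=NCCN1C(=S)SN1CCn2c1nsc2=S`; in this assay compound 2 gives >= 20000 nM, a limit of the assay.
- compound 3 `O=S(=O)(NC1=NCCN1C(=S)SN1CCn2c1nsc2=S)c1ccc(C(F)(F)F)cc1`; in this assay compound 3 gives >= 20000 nM, a limit of the assay.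

Compound 2 stands at the limit, and nothing separates it from the other two measured compounds: the limit of >= 20000 nM in this assay, at which 3 of the 3 values shown sit. All three measured steps, a step that the two limits leave unreadable from compound 1 to compound 2, a step that the two limits leave unreadable from compound 1 to compound 3 and a step that the two limits leave unreadable from compound 2 to compound 3, are therefore of unreadable size, and no trend in the aryl group on the sulfonyl sulfur can be drawn from them.

Compound 4 `COc1ccc(OC)c(S(=O)(=O)NC2=NCCN2C(=S)SN2CCn3c2nsc3=S)c1` differs from compound 2 by 2,5-dimethoxyphenyl in place of 2-methoxy-4-methylphenyl on a sulfonyl sulfur. The measured steps that bear on this change are the exchanges of the aryl group on the sulfonyl sulfur, a step that the two limits leave unreadable from compound 1 to compound 2 and a step that the two limits leave unreadable from compound 2 to compound 3, together with a step that the two limits leave unreadable from compound 1 to compound 3; none gives a readable size. No step beyond the scatter is expected in this assay, and the most likely outcome is a further limit. Compound 4 is expected to give about 30000 nM, in the range 10000 nM to 100000 nM. The estimated step from compound 2 to compound 4 is a step that the limit leaves unreadable from compound 2 to compound 4.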

Compound 4, concentration for 50% growth inhibition: >= 20000 nM
Compound 4 was reported as a limit; the forecaster's own chance of this, stated with the estimate: 85%; the middle value lies beyond the limit too.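

Compound 4 gives >= 20000 nM, a limit of the assay. The steps from compound 1, compound 2 and compound 3 to compound 4 therefore cannot be read: the limit of >= 20000 nM in this assay, at which 4 of the 4 values shown sit.

The compounds shown leave open whether any aryl group on the sulfonyl sulfur gives a readable value in this assay, and so how this group affects growth inhibition.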